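The source may report more compounds than this note shows. Statements on the series, on what has been measured and on what is new or still open speak of the compounds shown alone.

Measured compounds:
- compound 1 `O=c1c(Cl)c(CSC(=S)N2CCOCC2)oc2ccccc12`: 1800 nM
- compound 2 `COc1ccc2occ(CSC(=S)N3CCCCC3)c(=O)c2c1`: 6700 nM

Both were tested in a functional assay on SW480 cells (Homo sapiens) for antiproliferative activity, read by MTT assay, with a stated time of 72 h; on this read-out higher numbers stand for weaker inhibition and lower numbers for stronger inhibition. Compound 2 gives 6700 nM, the higher of the two numbers, so it is the weaker inhibitor here. Its nearest neighbour is compound 1, which gives 1800 nM, a lower number, and that gap lies beyond the scatter of repeated measurements. The two structures differ in more than one place, so no single change can be read from the pair.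

Compound 3 `COc1ccc2occ(CSC(=S)N3CCCC3)c(=O)c2c1` has not yet been measured. Going by the values given here, it keeps the core of compound 2 and changes only one group: pyrrolidin-1-yl in place of piperidin-1-yl on a thiocarbonyl carbon. This is a small change, one ring atom fewer in the ring that hangs on the thiocarbonyl carbon. Among the compounds with values here, no comparable step between measured compounds is available to show what such a change does on this core.

With nothing to point either way, compound 3 is expected to stay close to compound 2, with a step of a 1.1-fold lower number from compound 2 to compound 3 (0.05 log units; within the scatter), not beyond the scatter. The estimate for compound 3 in this assay is 6000 nM, with a range from 2500 nM to 14000 nM.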

Compound 3, half-maximal inhibitory concentration: 4800 nM
For compound 3 the middle estimate is 1.3-fold (0.10 log units) above the measured one; the measured number falls inside the stated range.
By their numbers in this assay, from the lowest: compound 1; then compounds 3 and 2 (each within the scatter of the next).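

In this assay, replacing piperidin-1-yl with pyrrolidin-1-yl on a thiocarbonyl carbon gives the only single-change comparison among these compounds (a 1.4-fold lower number from compound 2 to compound 3 (0.14 log units; within the scatter)). Going by these compounds alone, until now, no pair could show what a change at this position does. The two earlier compounds differed in more than one place. This pair shows that, on this core, a five-membered ring can stand in place of a six-membered one with no difference that can be told from the usual spread of repeated measurements, and nothing measured here accounts for that result.

Going by these compounds, the pair covers only these two ring sizes, so it remains open whether a larger azepane ring, an open-chain diethylamino group or a piperazine ring on the same carbon would also stay within the scatter of compound 2 and compound 3. Compound 1 differs from both of them in more than one place, so its value cannot be tied to any one group, and the effect of the chlorine or the methoxy group on the core remains unresolved.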